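This account rests on a few compounds, and the source may have more. Where it says the series, first, only, none or still open, it means among the compounds named here.

In a functional assay on MCF7 cells (Homo sapiens) for inhibition, with a stated time of 48 h (on this read-out lower numbers stand for stronger inhibition and higher numbers for weaker inhibition), compound 1 `COc1ccccc1Sc1c[nH]c2ccc(Cl)cc12` is reported only as a limit, > 2500 nM. Compound 2 `COc1cc(Sc2c[nH]c3ccc([N+](=O)[O-])cc23)cc(OC)c1OC` gives 560 nM, and compound 3 `COc1cc(Sc2c[nH]c3ccc(N)cc23)cc(OC)c1OC` gives 260 nM, the lower of the two actual numbers in this assay. Compound 3 therefore sets the mark for the next compound.

In compound 4 `COc1cc(Sc2c[nH]c3ccc(OCCO)cc23)cc(OC)c1OC`, 2-hydroxyethoxy takes the place of amino on an aromatic carbon of the shared core: 2-hydroxyethoxy in place of amino on an aromatic carbon. Within the data shown here, one measured step bears on this same place, amino in place of nitro on an aromatic carbon, and it is modest: a 2.2-fold lower number from compound 2 to compound 3 (0.33 log units; beyond the scatter). Among the measured compounds shown here, no measured step links compound 1 to the others, and 2-hydroxyethoxy itself has not been tested. A modest step is therefore expected again in this assay, more likely toward a higher number, given that compound 3 already holds the lowest number at 260 nM. The expected change is a 1.5-fold higher number from compound 3 to compound 4 (0.19 log units; within the scatter). For compound 4 the estimate is 400 nM, with an expected range from 130 nM to 1200 nM.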

Compound 4, half-maximal inhibitory concentration: 95 nM
Compound 4: middle estimate off by 4.2-fold (0.62 log units), on the high side; the measured number lies below the stated range.
By their numbers in this assay, from the lowest: compound 4; then compound 3; then compound 2. At a limit, above all of these: compound 1.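

In this assay, the position that had held only nitro and amino now carries 2-hydroxyethoxy, and the number falls further, with a 2.7-fold lower number from compound 3 to compound 4 (0.44 log units; beyond the scatter) and, against nitro, a 5.9-fold lower number from compound 2 to compound 4 (0.77 log units; beyond the scatter). Among these compounds, on this aromatic carbon, amino with 1 heavy atom gives way to a chain of 4 heavy atoms with no loss in this read-out, so the position takes a larger group than the earlier compounds showed. Nothing measured here gives a cause for this gain.

Going by these compounds, whether the gain needs the terminal hydroxyl or the chain alone stays open, as a plain methoxy or ethoxy group would be needed to separate the two. On these data alone, how far the position tolerates growth also stays open, for instance with a longer hydroxyalkoxy chain, a terminal amine or a carboxylic acid.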